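Trading Fluorine for Chlorine in a Cytotoxic Amide

The source may report more compounds than this note shows. Statements on the series, on what has been measured and on what is new or still open speak of the compounds shown alone.

- Compound 1 `O=C(Nc1cc(C(F)(F)F)cc(C(F)(F)F)c1)c1ccc(-c2ccccc2)cc1O`: 1580 nM
- Compound 2 `O=C(Nc1cc(C(F)(F)F)cc(C(F)(F)F)c1)c1cc(F)ccc1O`: 620 nM

Both numbers come from a functional assay on NALM-6 cells (Homo sapiens) for cytotoxicity, read by luminescence and CellTiter-Glo, with a stated time of 3 days (a higher number here means a weaker inhibitor, a lower number a stronger inhibitor), and can be compared directly. Compound 2 stands lowest of the pair at 620 nM and so is the stronger inhibitor, while compound 1 reads 1580 nM on the weaker side, a gap beyond the usual scatter. These two compounds differ in more than one place, so their gap does not show what any single swap does.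

Compound 3 `O=C(Nc1cc(C(F)(F)F)cc(C(F)(F)F)c1)c1ccc(Cl)cc1O` keeps the shared core and changes one group on the carbonyl carbon: 4-chloro-2-hydroxyphenyl in place of 5-fluoro-2-hydroxyphenyl on a carbonyl carbon is the whole difference from compound 2. For the measured compounds named here, no measured pair tests such a swap, so no direction can be favoured. The expected move, a 1.0-fold lower number from compound 2 to compound 3 (0.01 log units; within the scatter), is estimated to stay within the scatter. For compound 3 the estimated value is 600 nM, with an expected range from 230 nM to 1500 nM.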

Compound 3, half-maximal inhibitory concentration: 850 nM
For compound 3 the middle estimate is 1.4-fold (0.15 log units) below the measured one; measured number inside the range.
By their numbers in this assay, from the lowest: compounds 2, 3 and 1 (each within the scatter of the next, the first and the last beyond it).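

In this assay, 4-chloro-2-hydroxyphenyl in place of 5-fluoro-2-hydroxyphenyl on a carbonyl carbon gives a 1.4-fold higher number from compound 2 to compound 3 (0.14 log units; within the scatter) and so cannot be told apart from no change at all. Chloro in place of phenyl on an aromatic carbon gives a 1.9-fold lower number from compound 1 to compound 3 (0.27 log units; within the scatter) and likewise stays inside the normal spread of repeat measurements, so a small chloro and a whole phenyl ring are not separated at that place. No measured property of these compounds is available to explain either reading.

Going by these compounds, whether an amine, a methoxy group or a carboxylic acid on that aromatic carbon would shift the number beyond the scatter remains open. All the compounds shown also keep the hydroxy group and both trifluoromethyl groups, so what each of these contributes remains open too.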